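Compound 1 gives up its phenyl group

The source may report more compounds than this note shows. Statements on the series, on what has been measured and on what is new or still open speak of the compounds shown alone.

In an ADME assay on MT4 cells (Homo sapiens) for cytotoxicity (a lower number here means that less compound is tolerated, a higher number that more compound is tolerated), compound 1 `O=C(NC(=S)Nc1cccc(C(F)(F)F)c1)c1ccccc1` gives > 100000 nM, which is a limit of the assay and not a number. Compound 3 `CCNC(=S)Nc1cccc(C(F)(F)F)c1` gives > 100000 nM, which is likewise a limit. Only compound 2 `N#Cc1ccc(NC(=S)Nc2cccc(C(F)(F)F)c2)cc1` returns an actual number, 7000 nM. Compound 1 therefore stands at the limit of the series, with no exact value of its own.

Compound 4 `O=C(NC(=S)Nc1cccc(C(F)(F)F)c1)[C@H]1C[C@@H]2CC[C@H]1C2` keeps the core of compound 1 but exchanges the phenyl, on a carbonyl carbon, for a group with 2 five-membered non-aromatic rings of carbon only (a group of 7 heavy atoms (7 carbon; 2 five-membered non-aromatic rings of carbon only) in place of a group of 6 heavy atoms (6 carbon; one six-membered aromatic ring of carbon only), on a carbonyl carbon). For the measured compounds named here, no pair of measured compounds differs in one place, so the data offer no direct guide to this change. For compound 1 the expectation rests on (the limit of > 100000 nM in this assay, at which 2 of the 3 values shown sit). The estimated step of an at least 1.2-fold lower number from compound 1 to compound 4 (0.09 log units; that floor lies within the scatter) is small, either downward in this assay or none beyond the scatter, and the assay may again report only a limit. For compound 4 the expected value is 80000 nM, with an estimated range of 25000 nM to 100000 nM.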

Compound 4, half-maximal cytotoxic concentration: 42000 nM
Beside the measured number, compound 4's estimate is 1.9-fold (0.28 log units) above it, and the stated range covers the measured number.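

In this assay, for the compounds shown here, exchanging the phenyl on the carbonyl carbon for the group with 2 five-membered non-aromatic rings of carbon only gives the first step that can be read: an at least 2.3-fold lower number from compound 1 to compound 4 (0.37 log units; beyond the scatter). From the compounds shown here alone, compound 1 gives > 100000 nM, which is a limit and not a number, so the step is only a floor and its full size stays unknown. The change shows that the group on this carbonyl carbon can bring the reading off the limit, which the earlier compounds could not show, as their values offered no step at all: the limit of > 100000 nM in this assay, at which 2 of the 4 values shown sit.

Going by these compounds, whether an amine or a carboxylic acid on this carbonyl carbon would lower the number further or return it to the limit stays open. Also open, on these data alone, is whether the step follows the ring group as such or its 3 defined stereocentres.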